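Allyl to prop-1-yn-1-yl on the shared core

This account rests on a few compounds, and the source may have more. Where it says the series, first, only, none or still open, it means among the compounds named here.

Values in a functional assay on MT4 cells (Homo sapiens) for cytotoxicity (a lower number here means that less compound is tolerated, a higher number that more compound is tolerated), are as follows.
- compound 1 `CC1=C(N)[C@@]2(OS1(=O)=O)[C@@H](CO[Si](C)(C)C(C)(C)C)O[C@@H](n1cc(C)c(=O)n(C)c1=O)[C@@H]2O[Si](C)(C)C(C)(C)C` gives > 250000 nM as a limit of the assay
- compound 2 `C=CCC1=C(N)[C@@]2(OS1(=O)=O)[C@@H](CO[Si](C)(C)C(C)(C)C)O[C@@H](n1cc(C)c(=O)n(C)c1=O)[C@@H]2O[Si](C)(C)C(C)(C)C` gives 82000 nM as a plain number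

Going by the values given here, compound 2 holds the only actual number so far. Compound 3 `CC#CC1=C(N)[C@@]2(OS1(=O)=O)[C@@H](CO[Si](C)(C)C(C)(C)C)O[C@@H](n1cc(C)c(=O)n(C)c1=O)[C@@H]2O[Si](C)(C)C(C)(C)C` carries prop-1-yn-1-yl in place of allyl on a double-bonded ring carbon. Among the compounds with values here, the one measured step that bears on it is an at least 3.0-fold lower number from compound 1 to compound 2 (0.48 log units; beyond the scatter) and it concerns the same ring carbon. That step does not test this exchange, so no step beyond the scatter is expected in this assay here. The expected step is a 1.1-fold higher number from compound 2 to compound 3 (0.04 log units; within the scatter) and it stays within the scatter. For compound 3 the estimate is 90000 nM with an expected range from 35000 nM to 230000 nM.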

Compound 3, half-maximal cytotoxic concentration: 3300 nM
Beside the measured number, compound 3's estimate is 27-fold (1.44 log units) above it; the measured number lies below the stated range.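

The double-bonded ring carbon next to the ring sulfur responds to the kind of chain and not only to its size: with 3 carbon atoms in both groups, prop-1-yn-1-yl in place of allyl brings a 25-fold lower number from compound 2 to compound 3 (1.40 log units; beyond the scatter) in this assay. Prop-1-yn-1-yl in place of methyl brings an at least 75-fold lower number from compound 1 to compound 3 (1.87 log units; beyond the scatter). Compound 1 stands at a limit of the assay: the limit of > 250000 nM in this assay, at which 1 of the 3 values shown sits.

Open, as far as these compounds go, is whether the triple bond alone sets this level. A terminal ethynyl, a longer alkynyl chain or a phenyl group on this carbon could give a different number.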